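Lengthening an Alkoxy Chain on a Phosphodiesterase Inhibitor Core

This account rests on a few compounds, and the source may have more. Where it says the series, first, only, none or still open, it means among the compounds named here.

Compound 1 `COc1nc2c(c(=O)n(C)c(=O)n2C)n1CC(=O)NCc1ccccc1Cl` and compound 2 `CCOc1nc2c(c(=O)n(C)c(=O)n2C)n1CC(=O)NCc1ccccc1Cl` share one core, and compound 2 carries methyl in place of hydrogen on a saturated chain carbon bound to an oxygen on an aromatic ring. In an assay on isolated protein for inhibition of high affinity 3',5'-cyclic-AMP phosphodiesterase 7A (Homo sapiens), read by cAMP accumulation, with a stated time of 10 min (on this read-out lower numbers stand for stronger inhibition and higher numbers for weaker inhibition), compound 1 gives only a limit, > 200000 nM. Compound 2 also gives only a limit, > 200000 nM. The step that the two limits leave unreadable from compound 1 to compound 2 therefore cannot be sized, because of the limit of > 200000 nM in this assay, at which 2 of the 3 values shown sit. Compound 3 `CCCOc1nc2c(c(=O)n(C)c(=O)n2C)n1CCCC(=O)Nc1ccc(C(C)CC)cc1` rests on a second core; the difference between the two cores is not broken down here. In this assay compound 3 gives 9060 nM. Compound 4 `CCCCOc1nc2c(c(=O)n(C)c(=O)n2C)n1CCCC(=O)Nc1ccc(C(C)CC)cc1` differs from compound 3 by methyl in place of hydrogen on a saturated chain carbon, three bonds along the chain from an oxygen on an aromatic ring, the same kind of change as from compound 1 to compound 2, but at a different place: three bonds along the chain from an oxygen on an aromatic ring, rather than bound to an oxygen on an aromatic ring. The earlier step offers no readable size, so the expectation rests on compound 3 alone with its 9060 nM. The step is expected to be a 1.3-fold lower number from compound 3 to compound 4 (0.11 log units; within the scatter). Compound 4 is thus estimated at 7000 nM, most likely between 2500 nM and 20000 nM.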

Compound 4, half-maximal inhibitory concentration: 20000 nM
The estimate for compound 4 lay 2.9-fold (0.46 log units) below the measured number, and the stated range covers the measured number.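

In this assay, the added methyl on the second core gives a 2.2-fold higher number from compound 3 to compound 4 (0.34 log units; beyond the scatter), so here the change from propyl to butyl goes with weaker inhibition, by a modest step. The same kind of change on the core of compound 1 cannot be read and sits at a different place on the chain, so nothing shows whether the effect carries from one core to the other: the limit of > 200000 nM in this assay, at which 2 of the 4 values shown sit. A single readable step on one core sets no trend.

As far as these compounds go, whether a pentyl chain in place of the butyl would weaken inhibition further remains open. So does how an amine or a carboxylic acid on that chain would read on either core.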